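The source may hold more compounds than are shown below. What is called first, only, known or untested is meant among the compounds shown, and "the series" means these compounds.

Measured so far:
compound 1 `C=C(C)CCC[C@]1(C)C2=CCC[C@](C)(CC(=O)c3ccoc3)[C@H]2CC[C@H]1C`: > 100000 nM
compound 2 `C=C(C)CCC[C@]1(C)C2=CCC[C@](C)(C[C@H](OC(C)=O)C3=CC(=O)OC3O)[C@H]2CC[C@H]1C`: 3000 nM

In a functional assay on HL-60 cells (Homo sapiens) for antiproliferative activity, read by XTT assay, with a stated time of 72 h (on this read-out higher numbers stand for weaker inhibition and lower numbers for stronger inhibition), compound 1 gives > 100000 nM, which is a limit of the assay and not a number. Compound 2 gives a true number, 3000 nM.

Compound 3 `CC(C)=CCC[C@]1(C)C2=CCC[C@](C)(CC(=O)c3ccoc3)[C@H]2CC[C@H]1C` has the same atoms as compound 1, joined differently: 2-methylprop-1-en-1-yl in place of 2-methylprop-2-en-1-yl on a saturated chain carbon, two bonds along the chain from a saturated ring carbon. It carries 2-methylprop-1-en-1-yl in place of 2-methylprop-2-en-1-yl on a saturated chain carbon, two bonds along the chain from a saturated ring carbon.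

Going by the values given here, no measured step shows what this change does, so no shift beyond the usual scatter is expected. This expectation rests on compound 1, at > 100000 nM, again a limit. The expected change is a number no higher from compound 1 to compound 3 (the limit leaves the size open). The estimate for compound 3 is 100000 nM, with an expected range of 40000 nM to 200000 nM.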

Compound 3, half-maximal inhibitory concentration: 57800 nM
Estimate against measurement, compound 3: 1.7-fold (0.24 log units) above; low and high end bracket the measured number.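

In this assay, 2-methylprop-1-en-1-yl in place of 2-methylprop-2-en-1-yl on this saturated chain carbon gives an at least 1.7-fold lower number from compound 1 to compound 3 (0.23 log units; that floor lies within the scatter). Compound 3 gives a true number, 57800 nM, so this form of the chain has a value that can be compared with others. The real size of the step stays unknown, and only its floor can be read: the limit of > 100000 nM in this assay, at which 1 of the 3 values shown sits.

On these data alone, it remains open whether the same change would act alike on compound 2. Also open, as far as these compounds go, is what an amine or a carboxylic acid at this chain end would give.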